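Ketone and oxime on a triazole thioether: one open number

This account rests on a few compounds, and the source may have more. Where it says the series, first, only, none or still open, it means among the compounds named here.

The series rests on a shared core carrying a methoxyphenyl and an alkyl on the triazole, with a sulfur-linked chain to a phenyl-bearing group. Compound 1 `CCn1c(SCC(=O)c2ccccc2)nnc1-c1ccc(OC)cc1` carries an ethyl on the core and a benzoyl on the chain; in a functional assay on the whole organism (strain albino) for inhibition, with Rattus norvegicus as the target, read by paw edema, with a stated time of 4 h, at a dose of 0.28 mmol/kg by the oral route (on this read-out higher numbers stand for more inhibition at the one dose given (going by the name of the read-out) and lower numbers for less inhibition), compound 1 gives 70%. Compound 2 `C=CCn1c(SC/C(=N/O)c2ccccc2)nnc1-c1ccc(OC)cc1` carries an allyl on the core and an oxime in place of the carbonyl; in this assay compound 2 gives 76%. The two numbers lie within the usual scatter of each other, so compound 2 cannot be told apart from compound 1 on these data.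

Compound 3 `C=CCn1c(SCC(=O)c2ccccc2)nnc1-c1ccc(OC)cc1` keeps the allyl of compound 2 and differs from it only in the chain group: a group of 8 heavy atoms (7 carbon, 1 oxygen; one six-membered aromatic ring of carbon only) in place of a group of 9 heavy atoms (7 carbon, 1 nitrogen, 1 oxygen; one six-membered aromatic ring of carbon only), on a saturated chain carbon bound to a sulfur

Among the compounds with values here, no pair of measured compounds isolates this change. Compound 1, which already carries the benzoyl, gives 70%, so a step no larger than the scatter is expected, in either direction or none. In this assay compound 3 is estimated at 72%, with a range from 60% to 83%, an expected step of a number 4 percentage points lower from compound 2 to compound 3 (within the scatter).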

Compound 3, a percentage reported as inhibition, in the whole organism at one dose (the size of the read-out at that dose, not a potency): 67%
Beside the measured number, compound 3's estimate is 5 percentage points above it; the range from low to high includes it.
By their numbers in this assay, from the lowest: compounds 3, 1 and 2 (each within the scatter of the next).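

With the allyl held fixed, the benzoyl on a saturated chain carbon bound to a sulfur gives a number 9 percentage points lower from compound 2 to compound 3 (within the scatter) in this assay, so at this dose the oxime-bearing group and the benzoyl cannot be told apart. With the benzoyl held fixed, vinyl in place of methyl on a saturated chain carbon bound to an aromatic nitrogen, which turns the ethyl into the allyl, gives a number 3 percentage points lower from compound 1 to compound 3 (within the scatter), and this change cannot be resolved either. The two places that differed together between compound 1 and compound 2 can now be read one at a time, neither step leaves the scatter, and no independent measurement bears on these results.

On these data alone, all three compounds are read at one oral dose and one time point, so any difference in potency that this single percentage does not capture stays open. Also open, as far as these compounds go, is whether a carboxylic acid or an amine in place of the benzoyl, or a longer chain in place of the allyl, would give a step beyond the scatter.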